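The source may report more compounds than this note shows. Statements on the series, on what has been measured and on what is new or still open speak of the compounds shown alone.

Of the compounds shown here, two sharing one core have been tested in a functional assay on cells (Rhabdomyosarcoma cell, Homo sapiens) for cytotoxicity; a higher number here means a weaker inhibitor, a lower number a stronger inhibitor. Compound 1, `Cc1ccsc1C(c1ccccn1)N1CCN(c2ncnc3c2cnn3-c2ccccc2)CC1`, gives in this assay > 25000 nM, which is a limit of the assay and not a number. Compound 2, `c1ccc(C(c2nccs2)N2CCN(c3ncnc4c3cnn4-c3ccccc3)CC2)cc1`, gives in this assay > 25000 nM, again a limit rather than a measured number. Both results therefore sit at the limit of > 25000 nM in this assay, at which 2 of the 2 values shown sit. Compound 3, `Brc1ccc(C(c2ccccc2)N2CCN(c3ncnc4c3cnn4-c3ccccc3)CC2)cc1`, has not yet been tested in this assay. It differs from compound 2 in a single place: 4-bromophenyl in place of 1,3-thiazol-2-yl on a saturated chain carbon bound to an amine nitrogen in a ring and an aromatic carbon. Among the measured compounds shown here, no step between two measured compounds is available, so the change has to be judged from the two limits alone. On that basis the expected step is a step that the limit leaves unreadable from compound 2 to compound 3, that is, none beyond the scatter. Compound 3 is therefore expected to give 30000 nM in this assay, with a range from 10000 nM to 100000 nM.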

Compound 3, half-maximal inhibitory concentration: > 25000 nM
Compound 3: a limit, no number; the forecaster's own chance of this, stated with the estimate: 80%; the middle value lies beyond the limit too.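

In this assay compound 3 gives > 25000 nM, a limit of the assay and not a number. Among the compounds shown here, compound 2 also sits at a limit, so no step from compound 2 to compound 3 can be read. The compounds shown leave open whether swapping 1,3-thiazol-2-yl for 4-bromophenyl changes the potency at all.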